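A few compounds are considered here, and "the series" means these few. Any claim that something is new, unique, unknown or untested is made for them only; others in the source may bear on it.

Going by the values given here, compound 1 `COc1cc2ncnc(NNC(=S)NC(=O)c3ccccc3C)c2cc1OC` is the weakest of the three compounds measured so far: in a functional assay on MCF7 cells (Homo sapiens) for cytotoxicity, read by MTT assay, with a stated time of 72 h (on this read-out lower numbers stand for stronger inhibition and higher numbers for weaker inhibition), compound 1 gives 19300 nM. Compound 2 `Cc1ccc(C(=O)NC(=S)NNc2ncnc3ccccc23)cc1`, which carries the same thiosemicarbazide linker on an unsubstituted core, gives 7820 nM, and compound 3 `O=C(NC(=S)NNc1ncnc2ccccc12)c1cccc(Cl)c1` gives 3540 nM. The two values of compound 1 and compound 2 sit apart by more than the scatter, and the gap to compound 3 is wider still, so compound 1 sits at the top of the range in this assay. Among the compounds with values here, the single measured step between neighbours, a 2.2-fold lower number from compound 2 to compound 3 (0.34 log units; beyond the scatter), shows that swapping the aryl on the carbonyl carbon moves the number only modestly.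

Compound 4 `COc1cc2ncnc(NNC(=S)NC(=O)c3ccccc3)c2cc1OC` differs from compound 1 by hydrogen in place of methyl on an aromatic carbon. Within the data shown here, no measured step removes a methyl at this position, and the one step that does alter the benzoyl aryl was modest in size, so the change from compound 1 to compound 4 is expected to be small, at most a slight lowering of the number. Compound 4 is therefore estimated to give 14000 nM in this assay, within a range of 6000 nM to 33000 nM, which corresponds to an expected step of a 1.4-fold lower number from compound 1 to compound 4 (0.14 log units; within the scatter).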

Compound 4, half-maximal inhibitory concentration: 6990 nM
Compound 4: the middle estimate sits 2.0-fold (0.30 log units) above what was measured; the measured number falls inside the stated range.
By their numbers in this assay, from the lowest: compounds 3, 4 and 2 (each within the scatter of the next, the first and the last beyond it); then compound 1.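

In this assay, the change from 2-methylphenyl to phenyl gives a 2.8-fold lower number from compound 1 to compound 4 (0.44 log units; beyond the scatter), so this place on the aromatic ring, ortho to a large group, responds to the loss of a single methyl by more than the usual scatter. Going by these compounds alone, this is the first measured step on the core of compound 1 and the first to isolate this one group, whereas the earlier step, a 2.2-fold lower number from compound 2 to compound 3 (0.34 log units; beyond the scatter), exchanged 4-methylphenyl for 3-chlorophenyl on another core and so changed both the group and its place. The data shown offer no measurement that explains why this step occurs, and the single pair shows only that the methyl goes with the higher number here.

Going by these compounds, it remains open whether an ethyl group, a fluorine atom or an amine at this same place would give a number close to that of compound 1, close to that of compound 4, or outside both. On these data alone, it is also open whether adding a methyl at this place on the core of compound 2 would produce a step of similar size and direction.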